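A few compounds are considered here, and "the series" means these few. Any claim that something is new, unique, unknown or untested is made for them only; others in the source may bear on it.

Measured so far:
- compound 1, `CC(=N)N1CCC(Oc2ccc3ncn(Cc4ccc5ccc(C(=N)N)cc5c4)c3c2)CC1`: 50 nM
- compound 2, `CCCCc1nc2cc(OC3CCN(C(C)=N)CC3)ccc2n1Cc1ccc2ccc(C(=N)N)cc2c1`: 14 nM

Both numbers come from an assay on isolated protein for inhibition of serine protease 1 (Bos taurus); on this read-out higher numbers stand for weaker inhibition and lower numbers for stronger inhibition. Among the two, compound 1 stands with the higher number, so it is the weaker inhibitor of the pair; compound 2 gives a lower number, and the gap between them lies beyond the usual scatter of repeated measurements.

The next compound, compound 3, `CC(=N)N1CCC(Oc2ccc3nc(C(C)C)n(Cc4ccc5ccc(C(=N)N)cc5c4)c3c2)CC1`, has not yet been measured in this assay. It keeps the whole of compound 1 and changes one spot: isopropyl in place of hydrogen on an aromatic carbon. No measured step of exactly this kind exists among the compounds shown, so any expectation rests on the shape of the change and on the pair already known.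

A small carbon group added to the shared core is expected to help rather than hurt, because compound 2, which also carries a carbon group on its core, gives 14 nM. The step is expected to be modest and downward, estimated as a 2.5-fold lower number from compound 1 to compound 3 (0.40 log units; beyond the scatter). Compound 3 is therefore estimated at 20 nM, with a likely range from 8 nM to 50 nM.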

Compound 3, inhibition constant: 5.7 nM
Compound 3: the middle estimate sits 3.5-fold (0.55 log units) above what was measured; the measured number lies below the stated range.
By their numbers in this assay, from the lowest: compound 3; then compound 2; then compound 1.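

In this assay, putting isopropyl on the aromatic carbon between two ring nitrogen atoms gives an 8.8-fold lower number from compound 1 to compound 3 (0.94 log units; beyond the scatter) and so, with nothing else in compound 1 altered, ties a clear gain to this one position. Before this, the only hint was compound 2, which carries a different carbon chain at the same spot; now compound 3 at 5.7 nM and compound 2 at 14 nM show that two different carbon groups at this position both give numbers under that of the unsubstituted compound 1. Nothing shown here gives a measured reason why the added group lowers the number.

What remains open is how far this position can be pushed, since the compounds shown carry only hydrogen and simple carbon groups there, and a methyl group, a phenyl ring or a chain ending in a carboxylic acid could each behave differently. Going by these compounds, it is also open whether isopropyl would give a step of similar size on a different core or against a different protease, as this single pair in one assay cannot speak to either.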